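The compounds below may be only part of what the source reports. "The series", "measured", "known", "first", "only" and "open" are said of these compounds alone.

Measured compounds:
compound 1 `C=C1CCC(c2csc(/C=C(\C)C(N)=O)c2)CC1`: > 50000 nM (a limit)
compound 2 `C/C(=C\c1cc(-c2ccc(F)cc2)co1)C(N)=O`: > 50000 nM (a limit)
compound 3 `C/C(=C\c1cc(-c2cccnc2)co1)C(N)=O`: > 50000 nM (a limit)

In an ADME assay on NIH3T3 cells (Mus musculus) for cytotoxicity, read by CCK-8 assay, with a stated time of 24 h (a lower number here means a stronger inhibitor, a higher number a weaker inhibitor), compound 3 gives only a limit, > 50000 nM, and no number. Compound 1 likewise sits at a limit in this assay, > 50000 nM. Compound 2 also returns only a limit, > 50000 nM. All three therefore share one position: the limit of > 50000 nM in this assay, at which 3 of the 3 values shown sit. Going by the values given here, no compound in the set has a measured number, so no step between measured compounds can be read, and nothing in the data separates the two aryl groups on the furan or the thiophene core of compound 1 from one another.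

Compound 4 `C/C(=C\c1cc(-c2ccc(F)nc2)co1)C(N)=O` is the next member. It differs from compound 3 in one place: fluoro in place of hydrogen on an aromatic carbon, in words fluoro in place of hydrogen on an aromatic carbon. Among the compounds with values here, with no measured step to rest on, the expected step from compound 3 to compound 4 in this assay is none beyond the scatter, a step that the limit leaves unreadable from compound 3 to compound 4, and the most likely outcome is that compound 4 again reaches only the limit. The estimate for compound 4 is 80000 nM, expected to fall between 40000 nM and 200000 nM.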

Compound 4, half-maximal inhibitory concentration: > 50000 nM
Compound 4 gave a limit, no number (the forecaster's own chance of this, stated with the estimate: 85%); the middle value is on the limit's open side.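

No step can be read between compound 3 and compound 4, as both give only a limit in this assay: the limit of > 50000 nM in this assay, at which 4 of the 4 values shown sit.

The compounds shown leave open whether any member of the series gives a numerical value in this assay, and how their substituents would compare there.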